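This account rests on a few compounds, and the source may have more. Where it says the series, first, only, none or still open, it means among the compounds named here.

Three analogues of the shared core have been measured in an assay on cells for agonist activity at probable G-protein coupled receptor 34 (Mus musculus), with a stated time of 1 h; a higher number here means a larger maximal response, a lower number a smaller maximal response. Compound 1 `N[C@@H](COP(=O)(O)OCCCOC(=O)CCc1ccccc1OCc1cccc(OC2CCCCC2)c1)C(=O)O` gives 18.8%. Compound 2 `N[C@@H](COP(=O)(O)OCCCOC(=O)CCc1ccccc1OCc1cccc(Oc2ccc(Cl)cc2)c1)C(=O)O` gives 17.8%, and compound 3 `CC(C)(C)c1cccc(Oc2cccc(COc3ccccc3CCC(=O)OCCCOP(=O)(O)OC[C@H](N)C(=O)O)c2)c1` gives 19.9%. Compound 2 thus returns the lowest of the three numbers, but every step around it is within the scatter: a number 1 percentage points lower from compound 1 to compound 2 (within the scatter), a number 2.1 percentage points higher from compound 2 to compound 3 (within the scatter) and a number 1.1 percentage points higher from compound 1 to compound 3 (within the scatter). Changing the group on the oxygen of the aromatic ring from cyclohexyl to 4-chlorophenyl to 3-(tert-butyl)phenyl has left the maximal response essentially flat.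

Compound 4 `Cc1ccccc1-c1ccc(Oc2cccc(COc3ccccc3CCC(=O)OCCCOP(=O)(O)OC[C@H](N)C(=O)O)c2)cc1` extends this series: 2-methylphenyl in place of chloro on an aromatic carbon. The step bears most closely on the replacements of the 4-chlorophenyl already seen, from compound 1 to compound 2 and from compound 2 to compound 3, both within the scatter, so no step beyond the scatter is expected in this assay here either. Compound 4 is therefore estimated to give a maximal response of 19.5%, within 11% to 28%, which means an expected step of a number 1.7 percentage points higher from compound 2 to compound 4 (within the scatter).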

Compound 4, largest response reached (Emax), in percent of the reference or control that the assay uses: 13.4%
For compound 4 the middle estimate is 6.1 percentage points above the measured one; the range from low to high includes it.
By their numbers in this assay, from the lowest: compounds 4, 2, 1 and 3 (each within the scatter of the next).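

Working from compound 2, the chloro on an aromatic carbon para to a large group gives way to 2-methylphenyl, which adds a six-membered aromatic ring and raises the count from 1 heavy atom to 7, and in this assay this gives a number 4.4 percentage points lower from compound 2 to compound 4 (within the scatter) as the result of the change. Within the data shown here, the earlier compounds varied only the group on the oxygen, so this is the first reading at this aromatic carbon, and it shows that the position accepts a much larger group with no step beyond the scatter. No measurement at hand bears on the reason for this result.

Still open, as far as these compounds go, is whether an amine or a carboxylic acid at this aromatic carbon, in place of chloro, would give a step beyond the scatter. Also open, from the compounds shown here alone, is whether an unsubstituted phenyl there would read differently from 2-methylphenyl.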